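A few compounds are considered here, and "the series" means these few. Any claim that something is new, unique, unknown or untested is made for them only; others in the source may bear on it.

Measured compounds:
- compound 1 `CC(=O)c1cccc(-c2ccc(C(=O)N(Cc3cccc(OCCCCCC(=O)O)c3)C(C)C)cc2)c1`
- compound 2 `CCOc1cccc(-c2ccc(C(=O)N(Cc3cccc(OCCCCCC(=O)O)c3)C(C)C)cc2)c1`

In an ADME assay on Raji cells (Homo sapiens) for cytotoxicity, read by CellTiter-Glo and resazurin assay, with a stated time of 72 h (on this read-out higher numbers stand for an effect only at larger amounts of compound and lower numbers for an effect already at smaller amounts), compound 1 gives > 26000 nM, which is a limit of the assay rather than a number. In this assay compound 2 gives > 20800 nM, again a limit rather than a number. Compound 2 thus stands at one of the two limits shown, (the limit of > 20800 nM in this assay, at which 1 of the 2 values shown sits). Compound 1 stands at the other, (the limit of > 26000 nM in this assay, at which 1 of the 2 values shown sits). The step that the two limits leave unreadable from compound 1 to compound 2 is unreadable, both of its ends being limits.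

Compound 3 `CC(C)N(Cc1cccc(OCCCCCC(=O)O)c1)C(=O)c1ccc(-c2c[nH]c3ccccc23)cc1` arises from compound 2 by the change (1H-indol-3-yl in place of 3-ethoxyphenyl on an aromatic carbon). Among the measured compounds shown here, the only measured step in this assay is the one from compound 1 to compound 2, and it has no readable size, so no measured step gives a size for the change to compound 3. In this assay compound 3 is therefore expected to stay near the limit, with the step that the limit leaves unreadable from compound 2 to compound 3 expected to be small. The estimate for compound 3 is 25000 nM, with a range from 8000 nM to 80000 nM.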

Compound 3, half-maximal effective concentration: > 26000 nM
Compound 3: no number, only a limit (the forecaster's own chance of this, stated with the estimate: 75%); middle value at least 1.0-fold (0.01 log units) from the limit.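

In this assay, among the compounds shown here, compound 1, compound 2 and compound 3 all give limits rather than numbers, and no step among them can be read. The compounds shown leave open at what concentration any of them reaches its half-maximal effect, and whether exchanging these groups changes it.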